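The source may report more compounds than this note shows. Statements on the series, on what has been measured and on what is new or still open speak of the compounds shown alone.

Measured so far:

Compound 1, `Fc1ccc(/C=C\c2cc3ccccc3nc2Cl)cc1`, gives 20300 nM in a functional assay on MCF7 cells (Homo sapiens) for antiproliferative activity, read by sulforhodamine B assay, with a stated time of 72 h; a lower number here means a stronger inhibitor, a higher number a weaker inhibitor.
Compound 2, `Fc1ccc(/C=C\c2cc3ccc(Cl)cc3nc2Cl)cc1`, gives 16900 nM in this assay.
Compound 3, `FC(F)(F)c1cc(/C=C\c2cc3ccccc3nc2Cl)cc(C(F)(F)F)c1`, gives 7460 nM in this assay.

Compound 1 and compound 2 share a core and differ in one place: chloro in place of hydrogen on an aromatic carbon. That change made a 1.2-fold lower number from compound 1 to compound 2 (0.08 log units; within the scatter), a step too small to count as a real difference between the two. Among the measured compounds shown here, compound 3 carries a different core, and the difference between the two cores is not broken down here; its number in this assay is the lowest of the three so far, with compound 2 nearest to it and compound 1 furthest away.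

Compound 4, `FC(F)(F)c1cc(/C=C\c2cc3ccc(Cl)cc3nc2Cl)cc(C(F)(F)F)c1`, has not yet been measured. It differs from compound 3 by chloro in place of hydrogen on an aromatic carbon, the same change that turned compound 1 into compound 2, made at the same kind of place. Because that change produced a 1.2-fold lower number from compound 1 to compound 2 (0.08 log units; within the scatter), the expectation is that compound 4 will stay close to compound 3, with the step from compound 3 to compound 4 estimated at a 1.1-fold lower number from compound 3 to compound 4 (0.06 log units; within the scatter). On that basis the value of compound 4 in this assay is expected to be 6500 nM, most likely somewhere between 3500 nM and 12000 nM.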

Compound 4, half-maximal inhibitory concentration: 41700 nM
For compound 4 the middle estimate is 6.4-fold (0.81 log units) below the measured one; the whole stated range lies below it.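

The chloro change, carried to the second core, gave a 5.6-fold higher number from compound 3 to compound 4 (0.75 log units; beyond the scatter), and a higher number here means a weaker inhibitor. In this assay, among the compounds shown here, the same change therefore did not carry over from one core to the other, and its effect depended on the core that received it: the same change on two cores in this assay, a 1.2-fold lower number (0.08 log units; within the scatter) from compound 1 to compound 2 and a 5.6-fold higher number (0.75 log units; beyond the scatter) from compound 3 to compound 4, 6.7-fold (0.83 log units) apart, beyond the scatter of two such steps This is only one pair of steps, so it does not show which feature of the two cores sets them apart, why they respond differently, or how the change would behave on any further core.

As far as these compounds go, whether a methoxy group or an amine in place of the chloro would follow the small step seen on one core or the larger step seen on the other remains open. For the compounds shown here, also open is how the change would behave on a core carrying only one trifluoromethyl group, which could help show how much of the difference rests on that part of the structure.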